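A Silicon-Bearing Chain Added to Compound 3

The compounds below may be only part of what the source reports. "The series", "measured", "known", "first", "only" and "open" are said of these compounds alone.

Compound 1, `COc1cc(CC(O)(COCc2ccccc2)COCc2ccccc2)nc(OC)n1`, gives in a functional assay on HeLa cells (Homo sapiens) for antiproliferative activity, read by MTT assay, with a stated time of 72 h (on this read-out higher numbers stand for weaker inhibition and lower numbers for stronger inhibition), only an assay limit, > 100000 nM.
Compound 2, `O=c1cc(CC(O)(COCc2ccccc2)COCc2ccccc2)[nH]c(=O)[nH]1`, gives in this assay only an assay limit, > 100000 nM.
Compound 3, `COCn1c(CC(O)(CO)CO)cc(=O)[nH]c1=O`, gives in this assay only an assay limit, > 100000 nM.

For the measured compounds named here, the single pair of measured compounds that differ in one place is compound 1 and compound 2, and there the size of the change is hidden by the two limits: a step that the two limits leave unreadable from compound 1 to compound 2. Going by the values given here, compound 3 therefore stands where every value so far stands, at a limit and not at a number: the limit of > 100000 nM in this assay, at which 3 of the 3 values shown sit.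

Compound 4, `C[Si](C)(C)CCOCn1c(CC(O)(CO)CO)cc(=O)[nH]c1=O`, is the next compound to be measured. It differs from compound 3 in one place: a group of 5 heavy atoms (4 carbon, 1 silicon; no ring) in place of a hydrogen atom, on a saturated chain carbon bound to an oxygen on a saturated carbon. No measured step bears readably on such a change, since the only step shown, from compound 1 to compound 2, has no readable size, and all three values shown are limits of the same kind.

With nothing beyond three limits to build on, the expectation for compound 4 is that this assay will again report a limit rather than a number. Compound 4 is therefore estimated at 100000 nM, with a range from 30000 nM to 300000 nM. This estimate means an expected step of a number no higher from compound 3 to compound 4 (the limit leaves the size open), with the understanding that a value at the limit could hide any real size.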

Compound 4, half-maximal inhibitory concentration: > 100000 nM
Compound 4 ended at the assay's limit (the forecaster's own chance of this, stated with the estimate: 80%); the middle value sits exactly at the limit.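

In this assay compound 4 gives > 100000 nM, which is a limit of the assay. Compound 3 also stands at a limit, so the step between compound 3 and compound 4 cannot be read. The compounds shown leave open whether any change to the shared core would give a readable value, as all remain at one mark: the limit of > 100000 nM in this assay, at which 4 of the 4 values shown sit.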